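The source may hold more compounds than are shown below. What is called first, only, known or untested is meant among the compounds shown, and "the series" means these compounds.

Measured compounds in a functional assay on HT-29 cells (Homo sapiens) for antiproliferative activity, read by MTT assay, with a stated time of 48 h; a higher number here means a weaker inhibitor, a lower number a stronger inhibitor:
compound 1 `COc1ccc(N/C=C\C(=O)c2cn(-c3ccccc3)nc2-c2ccccc2)cc1` gives 1560 nM
compound 2 `COc1ccc(N/C=C\C(=O)c2cn(-c3ccccc3)nc2-c2ccc(F)cc2)cc1` gives 3200 nM
compound 3 `COc1ccc(-c2nn(-c3ccccc3)cc2C(=O)/C=C\Nc2ccc(Cl)cc2)cc1` gives 4760 nM

Compound 3 has the highest of the three numbers. Its nearest neighbour is compound 2, a gap within the scatter, so no order between compounds 2 and 3 can be read; its furthest is compound 1, a gap beyond the scatter. Compound 3 differs from compounds 1 and 2 in more than one place, so none of these gaps is a single-change step.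

Compound 4 `COc1ccc(N/C=C\C(=O)c2cn(-c3ccccc3)nc2-c2ccc(OC)cc2)cc1` is compound 3 with one change: methoxy in place of chloro on an aromatic carbon, that is, (4-chlorophenyl)amino becomes (4-methoxyphenyl)amino. Going by the values given here, the only single-change step among the measured compounds is a 2.1-fold higher number from compound 1 to compound 2 (0.31 log units; beyond the scatter), which concerns a different ring and a different group and so does not bear directly on this change. Among the compounds with values here, no measured pair reports chloro against methoxy on the anilino ring. The step from compound 3 to compound 4 in this assay is therefore expected to be small, a 1.4-fold lower number from compound 3 to compound 4 (0.13 log units; within the scatter), with the direction uncertain and a wide range allowed.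

Compound 4 is estimated at 3500 nM in this assay, within 1200 nM to 10000 nM.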

Compound 4, half-maximal inhibitory concentration: 8760 nM
The estimate for compound 4 lay 2.5-fold (0.40 log units) below the measured number; measured number inside the range.
By their numbers in this assay, from the lowest: compound 1; then compounds 2, 3 and 4 (each within the scatter of the next, the first and the last beyond it).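

In this assay, going from (4-chlorophenyl)amino to (4-methoxyphenyl)amino gives a 1.8-fold higher number from compound 3 to compound 4 (0.26 log units; within the scatter), so no preference between chloro and methoxy can be read at this position. Compound 4 also completes a set of three with the (4-methoxyphenyl)amino group held constant and only the substituent on the other aromatic ring varied: methoxy in place of fluoro gives a 2.7-fold higher number from compound 2 to compound 4 (0.44 log units; beyond the scatter), and methoxy in place of hydrogen gives a 5.6-fold higher number from compound 1 to compound 4 (0.75 log units; beyond the scatter), so with the earlier fluoro step the numbers rise from hydrogen through fluoro to methoxy across compound 1, compound 2 and compound 4. The data at hand offer no explanation for either the flat step or the rising order.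

As far as these compounds go, three substituents on one ring cannot show what governs that order, and it remains open whether a hydroxy, ethoxy or dimethylamino group there would extend the rise or break it. At the (4-methoxyphenyl)amino position, a single within-scatter pair leaves open whether the position tolerates change generally, which an amine or a carboxylic acid in place of methoxy would test more sharply.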